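Nitro-position swap in the bis-benzylidene cyclohexanone series

The source may hold more compounds than are shown below. What is called first, only, known or untested is meant among the compounds shown, and "the series" means these compounds.

Measured so far:
- compound 1 `CN(C)c1ccc(/C=C2\CCC/C(=C\c3cccc([N+](=O)[O-])c3)C2=O)cc1` — 32000 nM
- compound 2 `COc1cc(/C=C2\CCC/C(=C\c3cccc([N+](=O)[O-])c3)C2=O)cc(OC)c1OC` — 73000 nM
- compound 3 `CN(C)c1ccc(/C=C2\CCC/C(=C\c3ccc([N+](=O)[O-])cc3)C2=O)cc1` — 11000 nM

All three numbers come from a functional assay on HSC-2 cells (Homo sapiens) for cytotoxicity, with a stated time of 24 h; on this read-out lower numbers stand for higher toxicity in this test and higher numbers for lower toxicity in this test. Compound 2 gives the highest number of the three; the difference between its core and the core of compound 1 is not broken down here. Compound 3 differs from compound 1 by 4-nitrophenyl in place of 3-nitrophenyl on a double-bonded chain carbon bound to a double-bonded ring carbon, and in this assay that change gave a 2.9-fold lower number from compound 1 to compound 3 (0.46 log units; beyond the scatter).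

Compound 4 `COc1cc(/C=C2\CCC/C(=C\c3ccc([N+](=O)[O-])cc3)C2=O)cc(OC)c1OC` is not yet measured. Going by the values given here, it differs from compound 2 by 4-nitrophenyl in place of 3-nitrophenyl on a double-bonded chain carbon bound to a double-bonded ring carbon, the same change at the same place as the one between compound 1 and compound 3. Seen only twice in this set, the change so far produced one step of modest size, and a step of similar size is expected here, estimated as a 2.9-fold lower number from compound 2 to compound 4 (0.47 log units; beyond the scatter), resting on compound 2 at 73000 nM and on the one measured step.

Compound 4 is therefore expected to reach about 25000 nM, with 12000 nM to 55000 nM as the likely range.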

Compound 4, half-maximal cytotoxic concentration: 760 nM
Compound 4: the middle estimate sits 33-fold (1.52 log units) above what was measured; the measured number lies below the stated range.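

In this assay, 4-nitrophenyl in place of 3-nitrophenyl gave a 96-fold lower number from compound 2 to compound 4 (1.98 log units; beyond the scatter). The number fell on both cores, but the size of the step did not carry over from one core to the other: the same change on two cores in this assay, a 2.9-fold lower number (0.46 log units; beyond the scatter) from compound 1 to compound 3 and a 96-fold lower number (1.98 log units; beyond the scatter) from compound 2 to compound 4, 33-fold (1.52 log units) apart, beyond the scatter of two such steps

Going by these compounds alone, with only two pairs, these data do not show which feature of the cores goes with the larger step, or whether a further core would follow either step.

The compounds shown leave open whether the same gap between cores would appear with a nitrile or a trifluoromethyl group in place of the nitro group. From the compounds shown here alone, it also remains open whether a carboxylic acid at that place would keep any of the low number seen for compound 4 at 760 nM.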